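Chloro to tert-butoxy: working notes on the series

The source may hold more compounds than are shown below. What is called first, only, known or untested is meant among the compounds shown, and "the series" means these compounds.

Measured in a functional assay on A549 cells (Homo sapiens) for inhibition, read by MTT assay, with a stated time of 72 h; a lower number here means a stronger inhibitor, a higher number a weaker inhibitor
- compound 1 `COc1ccc(-c2nnc(SCCCN3CCN(c4nc5ccccc5s4)CC3)o2)cc1` gives 90300 nM
- compound 2 `Clc1ccc(-c2nnc(SCCCN3CCN(c4nc5ccccc5s4)CC3)o2)cc1` gives 110000 nM

Within the data shown here, compound 2 cannot be separated from compound 1, the only other measured compound. Compound 3 `CC(C)(C)Oc1ccc(-c2nnc(SCCCN3CCN(c4nc5ccccc5s4)CC3)o2)cc1` carries tert-butoxy in place of chloro on an aromatic carbon, which turns 4-chlorophenyl into 4-(tert-butoxy)phenyl: tert-butoxy in place of chloro on an aromatic carbon. Among the measured compounds shown here, the only measured step at this place is a 1.2-fold higher number from compound 1 to compound 2 (0.09 log units; within the scatter) (chloro in place of methoxy), so no step beyond the scatter is expected in this assay, and a single small step is thin evidence. The expected change is a 1.1-fold lower number from compound 2 to compound 3 (0.04 log units; within the scatter) in the estimate. For compound 3 the estimated value is 100000 nM (expected range 50000 nM to 200000 nM).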

Compound 3, half-maximal inhibitory concentration: 71600 nM
For compound 3 the middle estimate is 1.4-fold (0.15 log units) above the measured one; the range from low to high includes it.
By their numbers in this assay, from the lowest: compounds 3, 1 and 2 (each within the scatter of the next).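

In this assay, tert-butoxy in place of chloro gives a 1.5-fold lower number from compound 2 to compound 3 (0.19 log units; within the scatter), and tert-butyl in place of methyl on the oxygen gives a 1.3-fold lower number from compound 1 to compound 3 (0.10 log units; within the scatter); both steps are within the scatter. This position on the aromatic ring therefore takes tert-butoxy, with 5 heavy atoms, as well as chloro, with 1, and no step beyond the scatter appears among compounds 1, 2 and 3. No measurement here offers an explanation for this flat result. Going by these compounds, whether an amine or a carboxylic acid at this position would give a step beyond the scatter remains open. So does the effect of changes elsewhere in the shared core.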